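A few compounds are considered here, and "the series" means these few. Any claim that something is new, unique, unknown or untested is made for them only; others in the source may bear on it.

Compound 1 `CN(C)C1CCN(c2nccc3[nH]c(-c4cccc(OC(F)(F)F)c4)nc23)CC1`: 180000 nM
Compound 2 `CN1CCN(C2CCN(c3nccc4[nH]c(-c5cccc(OC(F)(F)F)c5)nc34)CC2)CC1`: 190000 nM

Both compounds were measured in a physicochemical assay for solubility, read by HPLC, using the shake flask method, in phosphate buffer, with a stated time of 20 h, at pH 6.5; a higher number here means a more soluble compound, a lower number a less soluble compound. Compound 2, at 190000 nM, stands level with compound 1 within the scatter. Among the compounds with values here, the one measured step, a 1.1-fold higher number from compound 1 to compound 2 (0.02 log units; within the scatter), puts 4-methylpiperazin-1-yl in place of dimethylamino on a saturated ring carbon.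

Compound 3 `CN1CCN(CC2CCN(c3nccc4[nH]c(-c5cccc(OC(F)(F)F)c5)nc34)CC2)CC1` has not yet been measured. Its difference from compound 2 is (4-methylpiperazin-1-yl)methyl in place of 4-methylpiperazin-1-yl on a saturated ring carbon. In words, (4-methylpiperazin-1-yl)methyl stands in place of 4-methylpiperazin-1-yl on a saturated ring carbon.

Within the data shown here, no measured step tests this change directly, and the evidence is thin, resting on a single pair. The nearest guide is the step to compound 2, a 1.1-fold higher number from compound 1 to compound 2 (0.02 log units; within the scatter), which also changed the group on a saturated ring carbon and stayed within the scatter. On that basis, no step beyond the scatter is expected in this assay, in either direction. The estimated step is a 1.1-fold lower number from compound 2 to compound 3 (0.05 log units; within the scatter). For compound 3 the expected value is 170000 nM, with an estimated range from 90000 nM to 300000 nM.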

Compound 3, solubility: 200000 nM
Compound 3: the middle estimate sits 1.2-fold (0.07 log units) below what was measured; measured number inside the range.
By their numbers in this assay, from the lowest: compounds 1, 2 and 3 (each within the scatter of the next).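

In this assay, the change from 4-methylpiperazin-1-yl to (4-methylpiperazin-1-yl)methyl on a saturated ring carbon gives a 1.1-fold higher number from compound 2 to compound 3 (0.02 log units; within the scatter), so this second change at the same position also stays within the scatter. Set against the dimethylamino group of compound 1, the same new group gives a 1.1-fold higher number from compound 1 to compound 3 (0.05 log units; within the scatter), and the three groups tried at this place, three ring bonds from the ring nitrogen, therefore stand level with one another in these three compounds. Nothing available explains why these numbers stay level.

As far as these compounds go, all three groups at this position contain a dimethylamino or 4-methylpiperazin-1-yl unit, so it remains open whether a group of another kind there, such as a carboxylic acid, a hydroxyl or a plain alkyl chain, would stay within the scatter as well. The core and its trifluoromethoxy group are the same throughout, which also leaves open how the numbers would respond if a nitrile or a methoxy group stood in place of that trifluoromethoxy group.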